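Swapping an Amide for a Thiadiazole on a Shared Core

The source may hold more compounds than are shown below. What is called first, only, known or untested is meant among the compounds shown, and "the series" means these compounds.

Of the compounds shown here, two of the same family have been measured in an assay on microsomes from liver for inhibition of acyl-CoA desaturase 1 (Rattus norvegicus); on this read-out higher numbers stand for weaker inhibition and lower numbers for stronger inhibition. Compound 1, `O=C(NCCC1CC1)c1ccc(N2CCC(Oc3ccccc3C(F)(F)F)CC2)nn1`, gives 14 nM. Compound 2, `Brc1cccc(OC2CCN(c3ccc(-n4ccnc4)nn3)CC2)c1`, gives 23 nM. Compound 1 has the lower of these two numbers, but the gap to compound 2 is within the scatter of the method, so the two cannot be told apart.

Compound 3, `CC(C)c1nnc(-c2ccc(N3CCC(Oc4ccccc4C(F)(F)F)CC3)nn2)s1`, has not yet been measured. It differs from compound 1 in one place: 5-isopropyl-1,3,4-thiadiazol-2-yl in place of (2-cyclopropylethyl)carbamoyl on an aromatic carbon. For the measured compounds named here, no measured pair shows this exact change, so its effect is unknown. Still, compound 2 carries an aromatic ring rather than an amide and gives 23 nM, which suggests that such a replacement is tolerated. The step from compound 1 to compound 3 in this assay is expected to be small, a 1.4-fold higher number from compound 1 to compound 3 (0.15 log units; within the scatter), likely within the scatter. Compound 3 is estimated at 20 nM, with a range from 5 nM to 80 nM.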

Compound 3, half-maximal inhibitory concentration: 8.8 nM
Beside the measured number, compound 3's estimate is 2.3-fold (0.36 log units) above it, and the stated range covers the measured number.
By their numbers in this assay, from the lowest: compounds 3, 1 and 2 (each within the scatter of the next, the first and the last beyond it).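

For the compounds shown here, this is the first pair that changes only this position, and in this assay it gives a 1.6-fold lower number from compound 1 to compound 3 (0.20 log units; within the scatter), so compound 1 and compound 3 cannot be told apart. The (2-cyclopropylethyl)carbamoyl group, with its amide hydrogen, can therefore give way to 5-isopropyl-1,3,4-thiadiazol-2-yl, which has 0 hydrogen-bond donors, with no measurable loss on this core, and the earlier hint from compound 2 now has a direct one-place comparison behind it. Nothing shown here explains why the two groups perform alike.

Still open, from the compounds shown here alone, is how much the isopropyl group on the thiadiazole contributes, and whether a methyl or a cyclopropyl group in its place would give a similar number. Going by these compounds, it is also open whether a very different group at this position, such as a carboxylic acid or a primary amine, would be tolerated on the same core.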